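Rearranged halogens on compound 2: expected effect on potency

The compounds below may be only part of what the source reports. "The series", "measured", "known", "first", "only" and "open" are said of these compounds alone.

The measurements come from a functional assay on A549 cells (Homo sapiens) for antiproliferative activity, read by MTT assay, with a stated time of 72 h; a lower number here means a stronger inhibitor, a higher number a weaker inhibitor. Compound 1 `CN(C)C/C=C/C(=O)Nc1cc2ncnc(Nc3ccc(F)c(Cl)c3)c2cc1O[C@@H]1CCOC1` gives 1900 nM in this assay. Compound 2 `C=CC(=O)Nc1cc2c(Nc3ccc(F)c(Cl)c3)ncnc2cc1OCc1cn(CCCCC(=O)NO)nn1` is built on the same shared core but carries a different side chain and a different tail. In this assay compound 2 reaches only the limit of the assay, > 50000 nM, so no number stands for it; this is the limit of > 50000 nM in this assay, at which 1 of the 2 values shown sits, the weakest result that can be recorded.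

Compound 3 `C=CC(=O)Nc1cc2c(Nc3cccc(Cl)c3F)ncnc2cc1OCc1cn(CCCCC(=O)NO)nn1` has not yet been measured. It has exactly the same atoms as compound 2, joined differently: 3-chloro-2-fluorophenyl in place of 3-chloro-4-fluorophenyl on a nitrogen on an aromatic ring. Going by the values given here, no measured pair in this set shows what such a move does, and compound 2 itself offers only a limit, not a number, to build from. The change keeps the same two halogens on the same ring and only redistributes them, with nothing measured here to show that this lifts a compound off the limit.

The step from compound 2 to compound 3 is therefore expected to be a number no higher from compound 2 to compound 3 (the limit leaves the size open), none beyond the scatter. Compound 3 is expected to give about 50000 nM, within a range from 10000 nM to 100000 nM, most likely again only as a limit.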

Compound 3, half-maximal inhibitory concentration: > 50000 nM
Compound 3 ended at the assay's limit; the forecaster's own chance of this, stated with the estimate: 70%; the middle value sits exactly at the limit.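

Compound 2 and compound 3 both end at a limit rather than at a number, so no step between them can be read, because neither gives a size to compare: the limit of > 50000 nM in this assay, at which 2 of the 3 values shown sit.

The compounds shown leave open whether 3-chloro-2-fluorophenyl in place of 3-chloro-4-fluorophenyl changes potency at all, and how weak either compound really is.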